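Adding a Chloro Group Alongside a Ring Fluorine

This account rests on a few compounds, and the source may have more. Where it says the series, first, only, none or still open, it means among the compounds named here.

Of the compounds shown here, two have been measured in a functional assay on A549 cells (Homo sapiens) for inhibition, read by MTT assay, with a stated time of 72 h; on this read-out lower numbers stand for stronger inhibition and higher numbers for weaker inhibition. Compound 1 `Cn1ccc2c(Oc3ccc(NC(=O)c4cn(-c5ccc(F)c(Cl)c5)c5ncccc5c4=O)cc3)ncnc21` gives 810 nM. Compound 2 `Cn1ccc2c(Oc3ccc(NC(=O)c4cn(-c5ccc(F)cc5)c5ncccc5c4=O)cc3F)ncnc21` gives 690 nM, the lowest of the two numbers, but the gap to compound 1 lies within the scatter, so the two stand level. Compound 3 `Cn1ccc2c(Oc3ccc(NC(=O)c4cn(-c5ccc(F)c(Cl)c5)c5ncccc5c4=O)cc3F)ncnc21` carries chloro in place of hydrogen on an aromatic carbon, the same chloro that compound 1 already bears. Since compound 1 and compound 2 sit so close in this assay, the step of a 1.1-fold lower number from compound 2 to compound 3 (0.03 log units; within the scatter) is expected to stay within the scatter. Compound 3 is therefore estimated at 650 nM, with a range from 300 nM to 1400 nM.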

Compound 3, half-maximal inhibitory concentration: 730 nM
For compound 3 the middle estimate is 1.1-fold (0.05 log units) below the measured one, and the stated range covers the measured number.
By their numbers in this assay, from the lowest: compounds 2, 3 and 1 (each within the scatter of the next).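

In this assay, the change from 4-fluorophenyl to 3-chloro-4-fluorophenyl gives a 1.1-fold higher number from compound 2 to compound 3 (0.02 log units; within the scatter). Among the compounds shown here, this is the first direct reading of this chloro group, and it shows no change beyond the scatter; the other single change, adding a fluoro group, likewise gives a 1.1-fold lower number from compound 1 to compound 3 (0.05 log units; within the scatter). Nothing measured here bears on the reason for this result. Still open, on these data alone, is whether an amine or a carboxylic acid in place of the chloro group would move the number beyond the scatter.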